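The source may hold more compounds than are shown below. What is called first, only, known or untested is meant among the compounds shown, and "the series" means these compounds.

Among the measured compounds shown here, compound 1 `Cn1c(N2CCCC2)c(C#N)c2c(N)ncnc21` is one of two compounds measured in an assay on isolated protein for binding affinity to Leucine-rich repeat serine/threonine-protein kinase 2 variant G2019S (Homo sapiens), read by TR-FRET and LanthaScreen, with a stated time of 2 h (a lower number here means a stronger inhibitor, a higher number a weaker inhibitor), in which compound 1 gives 125 nM. Compound 2 `Cn1c(-c2cccc(F)c2F)c(C#N)c2c(N)ncnc21` gives 11 nM in this assay. Of the two numbers, that of compound 1 is the highest, and the gap to compound 2 lies beyond the usual scatter of repeated measurements, so compound 1 is the weaker inhibitor of the pair. 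

Compound 3 `Cn1c(N)c(C#N)c2c(N)ncnc21` has not yet been measured in this assay. It differs from compound 1 in a single place: amino in place of pyrrolidin-1-yl on an aromatic carbon. The pyrrolidin-1-yl of compound 1 is thus replaced by a much smaller amino group on the same aromatic carbon of the shared core.

For the measured compounds named here, no measured pair shows what this kind of change does here, so the expectation rests only on compound 1 itself. The step from a 2.4-fold higher number from compound 1 to compound 3 (0.38 log units; beyond the scatter) is expected to be a moderate rise in the number, probably just beyond the scatter, since the group being lost is the larger of the two. Compound 3 is therefore estimated at 300 nM, with a range from 80 nM to 1200 nM.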

Compound 3, inhibition constant: 589 nM
Compound 3: middle estimate off by 2.0-fold (0.29 log units), on the low side; measured number inside the range.
By their numbers in this assay, from the lowest: compound 2; then compound 1; then compound 3.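

In this assay, cutting the pyrrolidin-1-yl back to an amino group gives a 4.7-fold higher number from compound 1 to compound 3 (0.67 log units; beyond the scatter), so this aromatic carbon of the shared core is sensitive to the group it carries, and here the smaller group gives the weaker inhibitor. Even so, compound 3 still gives 589 nM, so a measurable number remains with neither the pyrrolidin-1-yl ring nor its carbon atoms on this position. Nothing given here explains why the number rises on this change.

The step also changes several things at once: the ring and its carbon atoms leave, while a hydrogen-bond donor enters, so these two compounds cannot show which of these differences accounts for the rise. From the compounds shown here alone, a dimethylamino group, which would keep carbon atoms on the nitrogen without any ring, or a methylamino group, which would keep a hydrogen on that nitrogen alongside a single carbon, could help to separate them, and where such groups would fall relative to compound 1 and compound 3 remains open.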